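The source may hold more compounds than are shown below. What is called first, only, known or untested is meant among the compounds shown, and "the series" means these compounds.

Measured so far:
- compound 1 `Nc1scc(CN2CCN(c3ccc(OC(F)(F)F)cc3)CC2)c1C(=O)c1ccc(Cl)cc1`: 0% in a functional assay on CHO cells with adenosine receptor A1 (Homo sapiens) as the target, read by cAMP accumulation and immunoassay, with a stated time of 6 min, tested at 0.01 uM; on this read-out higher numbers stand for a weaker effect at the one concentration tested and lower numbers for a stronger effect
- compound 2 `Nc1scc(CN2CCN(c3cccc(F)c3)CC2)c1C(=O)c1cccc(C(F)(F)F)c1`: -11% in this assay

In this assay compound 1 gives 0%, the higher of the two numbers recorded, while compound 2 gives -11%, which sits lower by an amount beyond the usual scatter. Both numbers lie close to zero, so neither compound shows much effect at this concentration. Compound 3 `Nc1scc(CN2CCN(c3cccc(F)c3F)CC2)c1C(=O)c1ccc(Cl)cc1` has not yet been tested. It differs from compound 1 in one place: 2,3-difluorophenyl in place of 4-(trifluoromethoxy)phenyl on an amine nitrogen in a ring. Among the measured compounds shown here, no pair of measured compounds differing in exactly one place is available, so the step to compound 3 cannot be read off directly. Given that compound 1 and compound 2, with quite different groups on the same ring nitrogen, both sit near zero, the change to compound 3 is expected to bring no step beyond the scatter, so that a number 2 percentage points lower from compound 1 to compound 3 (within the scatter) is small. Compound 3 is therefore estimated at -2%, within a range from -15% to 12%.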

Compound 3, a percentage reported as activity, at one concentration (the size of the read-out at that concentration, not a potency): -13%
Compound 3: middle estimate off by 11 percentage points, on the high side, within the range that was stated.
By their numbers in this assay, from the lowest: compounds 3 and 2 (each within the scatter of the next); then compound 1.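

In this assay, placing 2,3-difluorophenyl instead of 4-(trifluoromethoxy)phenyl on the amine nitrogen in the ring gives a number 13 percentage points lower from compound 1 to compound 3 (beyond the scatter). Among the compounds shown here, this is the first change at this position that can be read on its own, and it shows that the group on this nitrogen can shift the read-out modestly towards a stronger effect at the one concentration tested. Nothing in the available data explains why the number moves.

One swap cannot show whether the step comes from adding the two fluorines or from removing the trifluoromethoxy group. An unsubstituted phenyl or a 4-methoxyphenyl on the same nitrogen would leave the core of compound 1 unchanged and could help to separate these two parts of the change.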